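Swapping the Sulfonyl Ring on the Longer Chain

This account rests on a few compounds, and the source may have more. Where it says the series, first, only, none or still open, it means among the compounds named here.

Of the compounds shown here, three that share one core have been measured in a functional assay on HepG2 cells (Homo sapiens) for cytotoxicity, read by MTT assay, with a stated time of 48 h; a higher number here means a weaker inhibitor, a lower number a stronger inhibitor. Compound 1 `CCCCCCCCCCCCNC(=O)[C@@H](NS(=O)(=O)c1ccc(C)cc1)[C@@H](C)O` gives 25800 nM. Compound 2 `CCCCCCCCCCCCNC(=O)[C@@H](NS(=O)(=O)c1cccs1)[C@@H](C)O` gives 25900 nM. Compound 3 `CCCCCCCCCCCCCCNC(=O)[C@@H](NS(=O)(=O)c1ccc(C)cc1)[C@@H](C)O` gives 10900 nM.

Two single changes connect these numbers. Compound 2 differs from compound 1 in that (thiophen-2-yl in place of 4-methylphenyl on a sulfonyl sulfur), and this change made a 1.0-fold higher number from compound 1 to compound 2 (0.00 log units; within the scatter). Compound 3 differs from compound 1 in that (ethyl in place of hydrogen on a saturated chain carbon, ten or more bonds along the chain from an amide-type nitrogen), and that change made a 2.4-fold lower number from compound 1 to compound 3 (0.37 log units; beyond the scatter). Compound 3 thus gives the lowest number of the three, and its gap to compound 2 also lies beyond the scatter.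

Compound 4 `CCCCCCCCCCCCCCNC(=O)[C@@H](NS(=O)(=O)c1cccs1)[C@@H](C)O` has not yet been measured. It differs from compound 3 in that (thiophen-2-yl in place of 4-methylphenyl on a sulfonyl sulfur). This is the same change that turns compound 1 into compound 2, made at the same place, on a sulfonyl sulfur whose other neighbours are a sulfonamide nitrogen; only the cores differ, by the longer chain described above. Because that change made a 1.0-fold higher number from compound 1 to compound 2 (0.00 log units; within the scatter) on the shorter-chain core, compound 4 is expected to show a 1.0-fold higher number from compound 3 to compound 4 (0.00 log units; within the scatter), a step that should again fall within the scatter. Compound 4 is therefore estimated to give 11000 nM, most likely between 5500 nM and 22000 nM, which would leave it close to compound 3 rather than near compound 1 or compound 2.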

Compound 4, half-maximal inhibitory concentration: 21600 nM
Compound 4: middle estimate off by 2.0-fold (0.29 log units), on the low side, and the stated range covers the measured number.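

In this assay, replacing 4-methylphenyl with thiophen-2-yl on the longer-chain core gives a 2.0-fold higher number from compound 3 to compound 4 (0.30 log units; within the scatter), while the longer chain with thiophen-2-yl already in place gives a 1.2-fold lower number from compound 2 to compound 4 (0.08 log units; within the scatter). When the ring swap is carried from the shorter-chain core to the longer-chain core, its two steps cannot be told apart, which shows that it transfers within the resolution of these data but does not prove that the two cores respond alike: the same change on two cores in this assay, a 1.0-fold higher number (0.00 log units; within the scatter) from compound 1 to compound 2 and a 2.0-fold higher number (0.30 log units; within the scatter) from compound 3 to compound 4, 2.0-fold (0.30 log units) apart, within the scatter of two such steps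

The chain change likewise cannot be told apart between the two sulfonyl groups, although one pair of steps shows only that no difference is resolved here, not that the steps are equal: the same change on two cores in this assay, a 2.4-fold lower number (0.37 log units; beyond the scatter) from compound 1 to compound 3 and a 1.2-fold lower number (0.08 log units; within the scatter) from compound 2 to compound 4, 2.0-fold (0.30 log units) apart, within the scatter of two such steps

The compounds shown leave open whether the same agreement would hold for a longer chain than that of compound 3 or for a chain carrying an amine. Going by these compounds, whether these steps would also agree in any read-out other than this assay remains open as well.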